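This account rests on a few compounds, and the source may have more. Where it says the series, first, only, none or still open, it means among the compounds named here.

In a functional assay on NCI-H522 cells (Homo sapiens) for inhibition, read by sulforhodamine B assay, with a stated time of 48 h, tested at 10 uM (a higher number here means more inhibition of growth at the concentration tested, a lower number less inhibition of growth), compound 1 (`COc1ccc(-c2nc3sc(-c4ccccc4)cn3n2)cc1`) gives 70% and compound 2 (`Clc1ccc(-c2cn3nc(-c4ccccc4)nc3s2)cc1`) gives 29% as the lower of the two numbers, beyond the scatter. These two compounds differ in more than one place, so their gap cannot be assigned to any single group. Compound 3 (`c1ccc(-c2nc3sc(-c4ccccc4)cn3n2)cc1`) comes from compound 2 by hydrogen in place of chloro on an aromatic carbon, para to a large group, so that 4-chlorophenyl becomes phenyl, with hydrogen in place of chloro on an aromatic carbon as the counted difference. Going by the values given here, no measured pair isolates this change, so the expectation rests on little. A modest upward move is expected since compound 2 at 29% sits well under compound 1 at 70% on this scale. The estimated step is a number 11 percentage points higher from compound 2 to compound 3 (beyond the scatter) and may not clear the scatter. In this assay compound 3 is estimated at 40% within an expected range of 15% to 65% overall.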

Compound 3, percent growth inhibition at one concentration: 19%
Estimate against measurement, compound 3: 21 percentage points above; low and high end bracket the measured number.
By their numbers in this assay, from the lowest: compounds 3 and 2 (each within the scatter of the next); then compound 1.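

In this assay, hydrogen in place of chloro, para to a large group, gives a number 10 percentage points lower from compound 2 to compound 3 (within the scatter), so at this position the change from 4-chlorophenyl to phenyl does not stand out from the scatter. Hydrogen in place of methoxy gives a number 51 percentage points lower from compound 1 to compound 3 (beyond the scatter), the only step shown that lies beyond the scatter, so within this pair the gap goes with the methoxy group alone. Compound 2 and compound 3 together therefore give no sign that chloro at its position does what methoxy does at its own.

Open, going by these compounds, is whether methoxy in the place held by chloro would give a step of similar size, and whether chloro in the place held by methoxy would. On these data alone, what an amine or a carboxylic acid would give in the place held by methoxy is also open. No measurement at hand explains either step.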